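The source may report more compounds than this note shows. Statements on the series, on what has been measured and on what is new or still open speak of the compounds shown alone.

In an assay on mitochondria for inhibition of Amine oxidase [flavin-containing] B (Rattus norvegicus) (a lower number here means a stronger inhibitor, a higher number a weaker inhibitor), two compounds have been measured. Compound 1 `NC(=O)CNCc1ccc(OCc2ccc([N+](=O)[O-])cc2)cc1` gives 9100 nM in this assay. Compound 2 `NC(=O)[C@@H](NCc1ccc(OCc2cccc(Cl)c2)cc1)c1ccccc1` gives 10100 nM in this assay, which is the higher of the two numbers, though compound 1 lies within the scatter of it, so the two cannot be ordered. Compound 3 `NC(=O)[C@@H](NCc1ccc(OCc2ccccc2)cc1)c1ccccc1` differs from compound 2 by a single change: hydrogen in place of chloro on an aromatic carbon. Going by the values given here, no measured pair shows this change, so its effect is not known. Compound 3 is expected to give a somewhat higher number than compound 2, a step of a 1.5-fold higher number from compound 2 to compound 3 (0.17 log units; within the scatter), possibly no more than the scatter, so that compound 3 is estimated at 15000 nM, within 5000 nM to 45000 nM.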

Compound 3, half-maximal inhibitory concentration: 73800 nM
Estimate against measurement, compound 3: 4.9-fold (0.69 log units) below, outside the stated range (above it).
By their numbers in this assay, from the lowest: compounds 1 and 2 (each within the scatter of the next); then compound 3.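

In this assay, putting hydrogen in place of chloro on an aromatic carbon, meta to a large group, gives a 7.3-fold higher number from compound 2 to compound 3 (0.86 log units; beyond the scatter) and so weakens inhibition. This position is therefore not indifferent to the change, and between these two compounds the 3-chlorobenzyl group goes with the stronger inhibition. Nothing available explains this step. On these data alone, whether fluoro, bromo or methoxy at this place would match chloro remains open. As far as these compounds go, it is also open whether chloro would act alike on the core of compound 1, which differs from compound 2 in more than one place.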